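Chloro Added to Compound 1

The compounds below may be only part of what the source reports. "The series", "measured", "known", "first", "only" and "open" are said of these compounds alone.

Of the compounds shown here, three sharing a core have been measured in a functional assay on DLD-1 cells (Homo sapiens) for antiproliferative activity, read by CellTiter-Glo, with a stated time of 72 h; a lower number here means a stronger inhibitor, a higher number a weaker inhibitor. Compound 3 `Cc1cc(C)c(S(=O)(=O)N2CCC(N3CCC(C(C)C)CC3)CC2)c(C)c1` gives 0.3 nM, compound 1 `CC1CCN(C2CCN(S(=O)(=O)c3cccc4ccccc34)CC2)CC1` gives 0.65 nM, and compound 2 `CC1CCN(C2CCN(S(=O)(=O)c3ccc(Br)cc3OC(F)(F)F)CC2)CC1` gives 5 nM. Compound 1 thus stands second highest of the three numbers: compound 3 sits at a lower number beyond the scatter, and compound 2 at a higher number, further beyond it. Compound 4 `CC1CCN(C2CCN(S(=O)(=O)c3ccc(Cl)c4ccccc34)CC2)CC1` differs from compound 1 by a single change: chloro in place of hydrogen on an aromatic carbon. Within the data shown here, no measured pair shows this change directly, so its size is unknown here. Compound 4 is expected to stay close to compound 1, with the estimated step of a 1.2-fold higher number from compound 1 to compound 4 (0.09 log units; within the scatter) not beyond the scatter in either direction. Compound 4 is therefore estimated at 0.8 nM, ranging from 0.25 nM to 2.5 nM.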

Compound 4, half-maximal inhibitory concentration: 0.1 nM
Beside the measured number, compound 4's estimate is 8.0-fold (0.90 log units) above it, outside the stated range (below it).
By their numbers in this assay, from the lowest: compound 4; then compound 3; then compound 1; then compound 2.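

Chloro in place of hydrogen on an aromatic carbon, para to a large group, is a change that this position accepts with a gain: in this assay it gives a 6.5-fold lower number from compound 1 to compound 4 (0.81 log units; beyond the scatter) and that step lies beyond the scatter. Among these compounds, the earlier compounds offered no pair differing in one place, so this is the first direct reading of any single change on the shared core. Nothing at hand accounts for the gain. On these data alone, whether fluoro, methyl or methoxy on this same carbon would give a similar step remains open. So does whether chloro would act alike on compound 2 or compound 3.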